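The source may hold more compounds than are shown below. What is called first, only, known or untested is meant among the compounds shown, and "the series" means these compounds.

Measured compounds:
compound 1, `CSCC[C@H](NC(=O)CN(c1nc(Cl)nc2[nH]cnc12)C1CC1)C(=O)OCc1ccccc1`, 44.6% in a functional assay on the whole organism (Tail, strain ICR) with Mus musculus as the target, in the tail flick test, with a stated time of 90 min, at a dose of 25 umol/kg by the oral route; a higher number here means a stronger effect of the compound at the dose given, a lower number a weaker effect
compound 2, `NC(=O)C[C@H](NC(=O)CN(c1nc(Cl)nc2[nH]cnc12)C1CC1)C(=O)OCc1ccccc1`, 32.3% in this assay
compound 3, `NC(=O)CC[C@H](NC(=O)CN(c1nc(Cl)nc2[nH]cnc12)C1CC1)C(=O)OCc1ccccc1`, 42.8% in this assay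

Compound 3 stands second of the three: its nearest neighbour is compound 1, a number 1.8 percentage points lower from compound 1 to compound 3 (within the scatter), and its furthest is compound 2, a number 10.5 percentage points higher from compound 2 to compound 3 (beyond the scatter). Compound 4, `C[C@@H](O)[C@H](NC(=O)CN(c1nc(Cl)nc2[nH]cnc12)C1CC1)C(=O)OCc1ccccc1`, is not yet measured. It differs from compound 3 as follows: 1-hydroxyethyl in place of 2-carbamoylethyl on a saturated chain carbon bound to an amide-type nitrogen and a carbonyl carbon. Among the compounds with values here, two measured steps bear on this side-chain swap: a number 12.3 percentage points lower from compound 1 to compound 2 (beyond the scatter) and a number 10.5 percentage points higher from compound 2 to compound 3 (beyond the scatter), both modest and beyond the scatter, and the shorter chain in compound 2 gave the lower number. A modest drop is therefore expected, a number 8.8 percentage points lower from compound 3 to compound 4 (within the scatter), and compound 4 is estimated at 34%, within 22% to 46%.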

Compound 4, a percentage reported as activity, at one dose (the size of the read-out at that dose, not a potency): 29.9%
For compound 4 the middle estimate is 4.1 percentage points above the measured one; the range from low to high includes it.
By their numbers in this assay, from the lowest: compounds 4 and 2 (each within the scatter of the next); then compounds 3 and 1 (each within the scatter of the next).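

In this assay, 1-hydroxyethyl, the first side chain here to carry a hydroxyl, sits low against the two longer chains: a number 12.9 percentage points lower from compound 3 to compound 4 (beyond the scatter) and a number 14.7 percentage points lower from compound 1 to compound 4 (beyond the scatter). Against carbamoylmethyl the result is a number 2.4 percentage points lower from compound 2 to compound 4 (within the scatter), so the low level at this position does not depend on a carbamoyl group. Nothing at hand explains these differences. From the compounds shown here alone, it remains open whether the hydroxyl or the shorter chain sets this level, since a plain ethyl chain would be needed to separate them. How an amine or a carboxylic acid at this position would compare is also unknown.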